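A few compounds are considered here, and "the series" means these few. Any claim that something is new, unique, unknown or untested is made for them only; others in the source may bear on it.

Measured so far in a functional assay for agonist activity at Free fatty acid receptor 1 (Homo sapiens), read by FLIPR, in the presence of a further agent that is not named here; a higher number here means that more compound is needed for the effect, a lower number that less compound is needed:
compound 1 `O=C1NC(=O)C(Cc2ccc(Oc3cccc(C(F)(F)F)n3)cc2)S1` — 1640 nM
compound 2 `Cc1cccc(Oc2ccc(CC3SC(=O)NC3=O)cc2)n1` — 2620 nM
compound 3 `Cc1cccnc1Oc1ccc(CC2SC(=O)NC2=O)cc1` — 1090 nM

Compound 3 has the lowest number of the three; against compound 2 the step is a 2.4-fold lower number from compound 2 to compound 3 (0.38 log units; beyond the scatter), the two cores differing as 3-methylpyridin-2-yl in place of 6-methylpyridin-2-yl on an oxygen on an aromatic ring. Against compound 1 the gap lies within the scatter, so no order is read there.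

The change trifluoromethyl in place of methyl on an aromatic carbon gave a 1.6-fold lower number from compound 2 to compound 1 (0.20 log units; within the scatter). Compound 4 `O=C1NC(=O)C(Cc2ccc(Oc3ncccc3C(F)(F)F)cc2)S1` is made from compound 3 by the same kind of change, (trifluoromethyl in place of methyl on an aromatic carbon); the surroundings differ, since in compound 1 the group is next to the ring nitrogen and meta to a large group, while in compound 4 it is ortho to a large group and two atoms from the ring nitrogen. Resting only on the step from compound 2 to compound 1, the step from compound 3 to compound 4 is expected to be a 1.5-fold lower number from compound 3 to compound 4 (0.16 log units; within the scatter). Compound 4 is estimated at 750 nM, between 300 nM and 1900 nM, the wider range reflecting the differing place.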

Compound 4, half-maximal effective concentration: 2290 nM
Compound 4: middle estimate off by 3.1-fold (0.48 log units), on the low side; measured number above the stated range.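

Trifluoromethyl in place of methyl on an aromatic carbon gave a 2.1-fold higher number from compound 3 to compound 4 (0.32 log units; beyond the scatter) in this assay. The change therefore does not carry over unchanged between these two cores: the same change on two cores in this assay, a 1.6-fold lower number (0.20 log units; within the scatter) from compound 2 to compound 1 and a 2.1-fold higher number (0.32 log units; beyond the scatter) from compound 3 to compound 4, 3.4-fold (0.53 log units) apart, beyond the scatter of two such steps

A step read on one core is thus no safe guide to the step on the other, but this does not show what sets the two apart: the group sits in a different place in each pair, and each step rests on a single pair of compounds.

Still open, going by these compounds, is how a chlorine atom, a nitrile or a methoxy group would behave in place of methyl on either core. Also open, on these data alone, is whether the gap between the two steps persists on other cores.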